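Carbonyl substituent exchange on a shared core

The source may hold more compounds than are shown below. What is called first, only, known or untested is meant among the compounds shown, and "the series" means these compounds.

Measured so far:
compound 1 `O=C(C1CC1)N1CCc2nc(C#Cc3ccccc3)sc2C1` — 290 nM
compound 2 `O=C(C1CCOCC1)N1CCc2nc(C#Cc3ccccc3)sc2C1` — > 10000 nM

In an assay on HEK293 cells for negative allosteric modulation of metabotropic glutamate receptor 5 (Homo sapiens), read by FLIPR, with a stated time of 1 h (a higher number here means a weaker inhibitor, a lower number a stronger inhibitor), compound 1 gives 290 nM. Compound 2 reaches only a limit of this assay, > 10000 nM; this is the limit of > 10000 nM in this assay, at which 1 of the 2 values shown sits, so no number is known for compound 2, only a bound. Among the compounds with values here, the single measured step, an at least 34-fold higher number from compound 1 to compound 2 (1.53 log units; beyond the scatter), is thus a large loss on changing the group on the carbonyl carbon.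

Compound 3 `O=C(N1CCCC1)N1CCc2nc(C#Cc3ccccc3)sc2C1` is not yet measured. Against compound 2 the change is pyrrolidin-1-yl in place of oxan-4-yl on a carbonyl carbon. Within the data shown here, the step from compound 1 to compound 2 bears on it only indirectly: it shows that the group on the carbonyl carbon can move the number by a large amount, but no measured pair shows what pyrrolidin-1-yl does at this place, and the starting point is a limit. A moderate gain relative to the limit of compound 2 is the expectation, with wide uncertainty and a real chance that compound 3 again returns only a limit. Compound 3 is estimated at 3000 nM, between 500 nM and 20000 nM. The estimated step is an at least 3.3-fold lower number from compound 2 to compound 3 (0.52 log units; beyond the scatter).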

Compound 3, half-maximal inhibitory concentration: > 10000 nM
Compound 3 was reported as a limit (the forecaster's own chance of this, stated with the estimate: 40%); at least 3.3-fold (0.52 log units) between middle value and limit.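

The value of compound 3, > 10000 nM, is a limit of this assay and not a number. Exchanging the cyclopropyl group for pyrrolidin-1-yl at the carbonyl gives an at least 34-fold higher number from compound 1 to compound 3 (1.53 log units; beyond the scatter), so among the compounds shown the large loss is no longer confined to oxan-4-yl, and it also appears with a five-membered ring carrying nitrogen as its hetero atom. The step between oxan-4-yl and pyrrolidin-1-yl cannot be read, and no order of the two groups can be given, because both compounds rest on the same bound: the limit of > 10000 nM in this assay, at which 2 of the 3 values shown sit.

Cyclopropyl remains the only group here with a measured number, so the compounds shown leave open whether a cyclobutyl or an isopropyl group on the carbonyl carbon would also give a number in this assay. They also leave open whether an open-chain dimethylamino group at this place would end at the same limit as pyrrolidin-1-yl, and how far the true values of compound 2 and compound 3 lie beyond that limit.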